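The source may hold more compounds than are shown below. What is called first, only, known or untested is meant among the compounds shown, and "the series" means these compounds.

Measured compounds:
- compound 1 `Clc1ncnc2ncn(Cc3ccccc3)c12`: 6%
- compound 2 `Fc1ccc(Cn2cnc3ncnc(Cl)c32)cc1`: 7%
- compound 3 `c1ccc(Cc2[nH]cnc3ncnc2-3)cc1`: 1%

All three were tested in an assay on isolated protein for inhibition of Rho-associated protein kinase 1 (Homo sapiens), tested at 30 uM; on this read-out higher numbers stand for more inhibition at the one concentration tested (going by the name of the read-out) and lower numbers for less inhibition. Compound 1 gives 6%, and its fluoro analogue compound 2 gives 7%. Going by the values given here, the single change between them is fluoro in place of hydrogen on an aromatic carbon, and it made a step of a number 1 percentage points higher from compound 1 to compound 2 (within the scatter), so the pair reads as flat. Compound 3 carries a different core; how its core differs from that of compound 1 is not broken down here. In this assay compound 3 gives 1%, and its gaps to compound 1 and to compound 2 both lie within the scatter, so no order among the three can be drawn.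

The unmeasured compound 4 `Fc1ccc(Cc2[nH]cnc3ncnc2-3)cc1` stands to compound 3 as compound 2 stands to compound 1: the change is fluoro in place of hydrogen on an aromatic carbon, and the place is described in the same words for both pairs, so it is the same change. Among the compounds with values here, on the only precedent, the step from compound 1 to compound 2 of a number 1 percentage points higher from compound 1 to compound 2 (within the scatter), the same change on the core of compound 3 is expected to produce a step of about a number 3 percentage points higher from compound 3 to compound 4 (within the scatter), that is, no movement beyond the scatter. Compound 4 is therefore estimated at 4% in this assay, with the expected range running from -6% to 14%.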

Compound 4, a percentage reported as inhibition, at one concentration (the size of the read-out at that concentration, not a potency): 2%
Beside the measured number, compound 4's estimate is 2 percentage points above it; the range from low to high includes it.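

In this assay, fluoro in place of hydrogen on an aromatic carbon, para to a large group, gives a step of a number 1 percentage points higher from compound 3 to compound 4 (within the scatter), and this step can be set against the one seen on the core of compound 1: the same change on two cores in this assay, a number 1 percentage points higher (within the scatter) from compound 1 to compound 2 and a number 1 percentage points higher (within the scatter) from compound 3 to compound 4, 0 percentage points apart, within the scatter of two such steps. On these two cores, then, the change carries over in the plain sense that it leaves the read-out flat on both, and the two steps give no sign that the core alters its outcome. Going by these compounds alone, this does not show that the change is without effect in general, since every step here lies within the scatter, only two cores are covered, and a read-out at one concentration gives no potency, so a dependence on the core that is smaller than the scatter would go unseen.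

On these data alone, it remains open whether any group on these cores can lift the read-out beyond the scatter, which leaves the fluoro comparison without a more responsive compound to be tested on. An amine, a carboxylic acid or a longer chain in place of fluoro on the aromatic ring of compound 4 would address this, and a further core would show whether the flat step holds more widely.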